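The source may report more compounds than this note shows. Statements on the series, on what has been measured and on what is new or still open speak of the compounds shown alone.

Compound 3 `CCc1ccc2c(c1)[n+]([O-])c(NCCN(C)C)n[n+]2[O-]` is the reference point of this note. In a physicochemical assay for solubility, in the presence of a further agent that is not named here (a lower number here means a less soluble compound, a higher number a more soluble compound), compound 3 gives > 49000000 nM, which is a limit of the assay and not a number. Compound 1 `[O-][n+]1nc(NCCN2CCCCC2)[n+]([O-])c2ccccc21` carries the same amine chain as compound 4 on an unsubstituted core. In this assay compound 1 gives > 49000000 nM, again a limit rather than a number. Compound 2 `[O-][n+]1nc(NCCN2CCCCC2)[n+]([O-])c2cc(Cl)ccc21` gives 3200000 nM in this assay. Among the compounds with values here, the only one-place step measured, an at least 15-fold lower number from compound 1 to compound 2 (1.18 log units; beyond the scatter), concerns the aromatic core and not the chain. Compound 3 therefore stands at the limit of > 49000000 nM in this assay, at which 2 of the 3 values shown sit, alongside compound 1, and no number has been resolved for it.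

Compound 4 `CCc1ccc2c(c1)[n+]([O-])c(NCCN1CCCCC1)n[n+]2[O-]` differs from compound 3 by piperidin-1-yl in place of dimethylamino on a saturated chain carbon, two bonds along the chain from a nitrogen on an aromatic ring. No measured step bears on this exchange; the single step shown, from compound 1 to compound 2, is a chloro-for-hydrogen change on the core. The piperidinyl chain is already present in compound 1, whose value > 49000000 nM is a limit. For compound 4 in this assay, no step beyond the scatter is expected, that is a step of a number no higher from compound 3 to compound 4 (the limit leaves the size open), and the read-out is expected to be a limit once more. Compound 4 is estimated at 49000000 nM, with a range from 20000000 nM to 100000000 nM.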

Compound 4, solubility: 39000000 nM
Compound 4: middle estimate off by 1.3-fold (0.10 log units), on the high side; the range from low to high includes it.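

In this assay compound 4 gives 39000000 nM, a resolved number for a piperidin-1-yl chain on the ethyl-bearing core. With the piperidin-1-yl chain held fixed, ethyl in place of chloro on an aromatic carbon comes with a 12-fold higher number from compound 2 to compound 4 (1.09 log units; beyond the scatter), a large step that, like an at least 15-fold lower number from compound 1 to compound 2 (1.18 log units; beyond the scatter), involves chloro on an aromatic carbon and not the amine on the chain. Only floors can be given for the two remaining steps, an at least 1.2-fold lower number from compound 3 to compound 4 (0.09 log units; that floor lies within the scatter) and an at least 1.2-fold lower number from compound 1 to compound 4 (0.09 log units; that floor lies within the scatter), and neither can be read further, because each starts from a limit and not a number: the limit of > 49000000 nM in this assay, at which 2 of the 4 values shown sit.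

Going by these compounds, whether piperidin-1-yl in place of dimethylamino changes the read-out at all therefore stays open, as does the effect of ethyl in place of hydrogen on the aromatic carbon. The compounds shown also leave open how a morpholin-4-yl group on the same saturated chain carbon, or a methoxy group on the aromatic carbon in place of ethyl or chloro, would read in this assay.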